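Shortening a Pentyl Chain on an Anilino Imide Core

A few compounds are considered here, and "the series" means these few. Any claim that something is new, unique, unknown or untested is made for them only; others in the source may bear on it.

Of the compounds shown here, three sharing a glutarimide-bearing imide core have been measured in an assay on FRT-Jurkat cells for inhibition of nuclear factor NF-kappa-B complex (Homo sapiens), read by flow cytometry, with a stated time of 24 h, tested at 10 uM; a lower number here means less inhibition, a higher number more inhibition at the concentration tested (going by the name of the read-out). Compound 1, `CCCCCc1ccc(Nc2ccc3c(c2)C(=O)N(C2CCC(=O)NC2=O)C3=O)cc1`, gives 12%. Compound 2, `O=C1CCC(N2C(=O)c3cccc(Nc4ccccn4)c3C2=O)C(=O)N1`, gives 1%. Compound 3, `CC(C)(C)c1ccc(Nc2cccc3c2C(=O)N(C2CCC(=O)NC2=O)C3=O)cc1`, gives 36%. Compound 1 thus stands second highest of the three, a number beyond the scatter above compound 2 and beyond the scatter below compound 3.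

The unmeasured compound 4, `CCc1ccc(Nc2ccc3c(c2)C(=O)N(C2CCC(=O)NC2=O)C3=O)cc1`, differs from compound 1 in one place: hydrogen in place of propyl on a saturated chain carbon, two bonds along the chain from an aromatic carbon. Read one bond further out, the pentyl chain of compound 1 becomes the ethyl chain of compound 4.

Among the measured compounds shown here, the only step between measured compounds, a number 35 percentage points higher from compound 2 to compound 3 (beyond the scatter), concerns a change at the nitrogen on the aromatic ring, not the chain; it does not bear on the present change. For the measured compounds named here, nothing among the measured compounds shows what shortening this chain does. The expectation is therefore a step of a number 4 percentage points lower from compound 1 to compound 4 (within the scatter), that is, a number close to that of compound 1, within the scatter or slightly lower. Compound 4 is estimated at 8%, in a range from -6% to 22%.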

Compound 4, a percentage reported as inhibition, at one concentration (the size of the read-out at that concentration, not a potency): 5%
Compound 4: middle estimate off by 3 percentage points, on the high side; the measured number falls inside the stated range.
By their numbers in this assay, from the lowest: compounds 2, 4 and 1 (each within the scatter of the next, the first and the last beyond it); then compound 3.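

Read in this assay, the first direct test of this chain gives a number 7 percentage points lower from compound 1 to compound 4 (within the scatter), so the pentyl chain of compound 1 and the ethyl chain of compound 4 cannot be told apart in this read-out. On this core and at this place, on a saturated chain carbon two bonds along from an aromatic carbon, swapping the outer propyl for hydrogen takes away 3 heavy atoms with no change that rises above the usual scatter, a finding that holds for this one pair and at this one tested concentration. Why the two compounds read alike cannot be said, as no measurement offers an explanation for this result.

Only the pentyl and ethyl chains are shown on this core, so a longer chain such as octyl, or the shorter methyl, could still give a different picture. Also open is what a chain ending in an amine or a carboxylic acid would do at this place, since both chains shown here consist of carbon and hydrogen alone.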